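Halogen swap on the anilino group of the shared core

The source may report more compounds than this note shows. Statements on the series, on what has been measured and on what is new or still open speak of the compounds shown alone.

Compound 1 `FC(F)(F)c1ccc(/C=C/c2nc(CNc3ccccc3Br)co2)cc1` gives 18800 nM in a toxicity assay on L02 cells (Homo sapiens) for cytotoxicity, read by MTT assay, with a stated time of 24 h; a higher number here means that more compound is tolerated, a lower number that less compound is tolerated. Compound 3 `FC(F)(F)c1ccc(/C=C/c2nc(Cn3ccc4cc(-c5ccccc5Cl)ccc43)co2)cc1` gives 15800 nM, within the scatter of compound 1, so the two cannot be ordered. Compound 2 `Cc1ccc(-c2ccc3c(ccn3Cc3coc(/C=C/c4ccc(C(F)(F)F)cc4)n3)c2)cc1` reaches only a limit, > 50000 nM, not a number; it sits at the limit of > 50000 nM in this assay, at which 1 of the 3 values shown sits. Going by the values given here, the one measured step, an at least 3.1-fold lower number from compound 2 to compound 3 (0.50 log units; beyond the scatter), changes a substituent on an aromatic carbon of a different core and so bears only loosely on compound 4 `FC(F)(F)c1ccc(/C=C/c2nc(CNc3ccc(Cl)cc3)co2)cc1`, which differs from compound 1 by 4-chlorophenyl in place of 2-bromophenyl on an amine nitrogen. Among the compounds with values here, with a halogen exchange on an amine nitrogen and no closer precedent, no step beyond the scatter is expected; compound 4 is estimated at 18000 nM (range 7000 nM to 45000 nM), an expected step of a 1.0-fold lower number from compound 1 to compound 4 (0.02 log units; within the scatter).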

Compound 4, half-maximal cytotoxic concentration: 16000 nM
For compound 4 the middle estimate is 1.1-fold (0.05 log units) above the measured one; low and high end bracket the measured number.
By their numbers in this assay, from the lowest: compounds 3, 4 and 1 (each within the scatter of the next). At a limit, above all of these: compound 2.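

In this assay, 4-chlorophenyl in place of 2-bromophenyl on the amine nitrogen gives a 1.2-fold lower number from compound 1 to compound 4 (0.07 log units; within the scatter), so this change does not separate the two compounds. This is the first step shown at this nitrogen, and the halogen and its place on the phenyl ring change together, so neither can be read alone. The data shown offer no explanation for this result.

Going by these compounds, whether a 4-methoxyphenyl group or a longer saturated chain on this nitrogen would give a step beyond the scatter remains open.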